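The source may report more compounds than this note shows. Statements on the series, on what has been measured and on what is new or still open speak of the compounds shown alone.

Compound 2 `COC(=O)c1cc(Cl)ccc1OC(=O)COc1cc(O)c2c(=O)cc(-c3ccccc3)oc2c1` is known in an ADME assay on cells (T-cell, Mus musculus, strain BALB/c) for cytotoxicity, read by MTT assay, with a stated time of 48 h (on this read-out higher numbers stand for lower toxicity in this test and lower numbers for higher toxicity in this test), only as a limit, > 436000 nM. Compound 2 thus sits at the limit of > 436000 nM in this assay, at which 1 of the 3 values shown sits. Compound 1 `COC(=O)c1c(F)cccc1OC(=O)COc1cc(O)c2c(=O)cc(-c3ccccc3)oc2c1` gives 319000 nM in this assay, and compound 3 `COC(=O)c1c(Br)cc(Br)cc1OC(=O)COc1cc(O)c2c(=O)cc(-c3ccccc3)oc2c1` gives 398000 nM, so the three measured compounds stand close together. Compound 4 `COC(=O)c1c(Br)cccc1OC(=O)COc1cc(O)c2c(=O)cc(-c3ccccc3)oc2c1` carries a group of 11 heavy atoms (8 carbon, 2 oxygen, 1 bromine; one six-membered aromatic ring of carbon only) in place of a group of 11 heavy atoms (8 carbon, 2 oxygen, 1 chlorine; one six-membered aromatic ring of carbon only), on an oxygen next to a carbonyl group. Going by the values given here, only one measured step bears on this change, an at least 1.3-fold higher number from compound 1 to compound 2 (0.13 log units; that floor lies within the scatter), and it lies within the scatter, so for compound 4 no step beyond the scatter is expected in this assay either. Compound 4 is therefore expected to give 400000 nM, between 250000 nM and 640000 nM. The step this estimate means is an at least 1.0-fold lower number from compound 2 to compound 4 (0.03 log units; that floor lies within the scatter), which is expected to stay within the scatter.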

Compound 4, half-maximal cytotoxic concentration: 388000 nM
The estimate for compound 4 lay 1.0-fold (0.01 log units) above the measured number, and the stated range covers the measured number.
By their numbers in this assay, from the lowest: compounds 1, 4 and 3 (each within the scatter of the next). At a limit, above all of these: compound 2.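

Bromo in place of fluoro on an aromatic carbon hardly registers in this assay, with a 1.2-fold higher number from compound 1 to compound 4 (0.09 log units; within the scatter), and hydrogen in place of bromo on an aromatic carbon does no more, with a 1.0-fold lower number from compound 3 to compound 4 (0.01 log units; within the scatter). Replacing the 4-chloro-2-(methoxycarbonyl)phenyl group yields only a floor, an at least 1.1-fold lower number from compound 2 to compound 4 (0.05 log units; that floor lies within the scatter), so the true size of that step cannot be read. The number for compound 2 is a limit: the limit of > 436000 nM in this assay, at which 1 of the 4 values shown sits.

The compounds shown leave open whether an amine or a carboxylic acid on this aromatic ring would give a step beyond the scatter.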